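This account rests on a few compounds, and the source may have more. Where it says the series, first, only, none or still open, it means among the compounds named here.

Series notes. Three compounds have numbers in an assay on CHO cells for antagonist activity at melanin-concentrating hormone receptor 1 (Homo sapiens), read by luminescence and calcium flux, with a stated time of 10 min; a lower number here means a stronger inhibitor, a higher number a weaker inhibitor. Compound 1 `N#Cc1cccc(-c2ccc(C(=C3CCN(CC4CC4)CC3)c3nc4cc(C(F)(F)F)c(F)cc4[nH]3)cc2)c1` gives 3.5 nM there. Compound 3 `CN1CCN(CCCN(c2nc3cc(F)c(Cl)cc3[nH]2)[C@@H]2CC[C@]3(c4ccc(C#N)cc4)C[C@@H]3C2)CC1` gives 4.9 nM in this assay, and compound 2 `Cc1ccc(CN2CCC(Cc3ccc(C(=O)N[C@H](C)c4ccc(Br)cc4)cc3)CC2)c(C)c1` gives 105 nM. Compound 1 has the lowest of the three numbers; the gap to compound 3 lies within the usual scatter, so the two are not separated, while the gap to compound 2 lies beyond it.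

Compound 4 `Fc1cc2[nH]c(C(=C3CCN(CC4CC4)CC3)c3ccc(-c4cncnc4)cc3)nc2cc1C(F)(F)F` has not been measured. Relative to compound 1 the change is pyrimidin-5-yl in place of 3-cyanophenyl on an aromatic carbon, placed on an aromatic carbon of a six-membered aromatic ring of carbon only, para to a large group. Within the data shown here, no measured pair in the set shows this exchange, so nothing in the numbers sets its size. The expectation is a small step toward a higher number, at or just beyond the scatter, from compound 1 to compound 4 in this assay of a 2.3-fold higher number from compound 1 to compound 4 (0.36 log units; beyond the scatter). Compound 4 is therefore estimated at 8 nM in this assay, within a range of 2.5 nM to 30 nM.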

Compound 4, half-maximal inhibitory concentration: 95 nM
Compound 4: the middle estimate sits 12-fold (1.07 log units) below what was measured; the measured number lies above the stated range.
By their numbers in this assay, from the lowest: compounds 1 and 3 (each within the scatter of the next); then compounds 4 and 2 (each within the scatter of the next).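

In this assay, among these compounds, pyrimidin-5-yl in place of 3-cyanophenyl, on an aromatic carbon para to a large group, brings a 27-fold higher number from compound 1 to compound 4 (1.43 log units; beyond the scatter) and marks this position as sensitive to the group it carries, which the earlier compounds, with no single-place pair among them, could not show. The step is large, and it rests on this one pair on the core of compound 1. The exchange removes the carbon-only ring and the nitrile together and brings in a ring with two hetero atoms, and nothing available bears on why the number rises.

The compounds shown leave open whether the loss follows the nitrile or the ring nitrogens. Unsubstituted phenyl and pyridin-3-yl at this position would separate these two changes, and a 4-cyanophenyl group would test where the nitrile sits.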